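A few compounds are considered here, and "the series" means these few. Any claim that something is new, unique, unknown or untested is made for them only; others in the source may bear on it.

Two compounds share a core built around a bicyclic ketone ether linked through an amide chain to a central benzene ring, which carries a second amide. Compound 1 `CC(C)(C)c1ccc(C(=O)Nc2cccc(NC(=O)COc3ccc4c(=O)ccoc4c3)c2)cc1` ends that second amide with a tert-butyl-bearing ring, and compound 2 `N#Cc1ccc(C(=O)Nc2cccc(NC(=O)COc3ccc4c(=O)ccoc4c3)c2)cc1` with a cyano-bearing ring. In an assay on isolated protein for inhibition of Rho-associated protein kinase 2 (Homo sapiens), read by scintillation counting, radiometric assay and 33P incorporation, with a stated time of 40 min, in the presence of a further agent that is not named here (a higher number here means a weaker inhibitor, a lower number a stronger inhibitor), compound 1 gives 34 nM, and compound 2 gives 15 nM. For the measured compounds named here, the single measured step, a 2.3-fold lower number from compound 1 to compound 2 (0.36 log units; beyond the scatter), shows that this change at the end of the second amide brought a modest gain. Going by the values given here, compound 2 therefore holds the lower of the two numbers, with compound 1 the only neighbour.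

Compound 3 `Cc1nc(C(=O)Nc2cccc(NC(=O)COc3ccc4c(=O)ccoc4c3)c2)cs1` changes a different part: 2-methyl-1,3-thiazol-4-yl in place of 4-cyanophenyl on a carbonyl carbon. Among the compounds with values here, no measured step shows the effect of swapping the whole ring, so the step from compound 1 to compound 2 bears on it only loosely, as a sign that this end of the molecule tolerates change. A small loss, near the edge of scatter, is the most reasonable expectation. Compound 3 is expected to give 30 nM, with a plausible range from 10 nM to 90 nM. This corresponds to an expected step of a 2.0-fold higher number from compound 2 to compound 3 (0.30 log units; within the scatter).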

Compound 3, half-maximal inhibitory concentration: 33 nM
Compound 3: the middle estimate sits 1.1-fold (0.04 log units) below what was measured; the measured number falls inside the stated range.
By their numbers in this assay, from the lowest: compound 2; then compounds 3 and 1 (each within the scatter of the next).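

The result shows something the first pair could not: at this carbonyl carbon the whole ring can be exchanged, not just the group it carries, and a five-membered aromatic ring with 2 hetero atoms still gives a number in the same range in this assay. The exchange of 4-cyanophenyl for 2-methyl-1,3-thiazol-4-yl costs a modest amount, with a 2.2-fold higher number from compound 2 to compound 3 (0.34 log units; beyond the scatter), so compound 2 keeps the lowest number of the three, while a 1.0-fold lower number from compound 1 to compound 3 (0.01 log units; within the scatter) leaves the 4-(tert-butyl)phenyl and 2-methyl-1,3-thiazol-4-yl compounds indistinguishable. No supporting data are available to explain why these rings compare as they do.

From the compounds shown here alone, what the methyl on the thiazole contributes remains open, as does how a thiazole carrying a nitrile in its place would compare with compound 3. It is equally unclear how far this tolerance extends, for instance to a pyridine ring or to a ring bearing an amine or a carboxylic acid.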